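The compounds below may be only part of what the source reports. "The series", "measured", "known", "first", "only" and "open" are said of these compounds alone.

Compound 1 `Cc1cc(CC(=O)O)ccc1-c1noc(-c2ccc(C3CCCCC3)cc2)n1` gives 4000 nM in a functional assay on CHO cells for agonist activity at sphingosine 1-phosphate receptor 5 (Homo sapiens), read by GTPgammaS binding; a lower number here means that less compound is needed, a higher number that more compound is needed for the effect.
Compound 2 `Cc1cc(CCC(=O)O)ccc1-c1noc(-c2ccc(OC(C)C)c(C(F)(F)F)c2)n1` gives 40 nM in this assay.
Compound 3 `CCOc1ccc(-c2nc(-c3ccc(CCC(=O)O)cc3C)no2)cc1C(F)(F)F` gives 260 nM in this assay.

Among these three numbers compound 3 stands second highest; its nearest neighbour is compound 2, while compound 1 lies furthest away with a higher number. Compound 4 `COc1ccc(-c2nc(-c3ccc(CCC(=O)O)cc3C)no2)cc1C(F)(F)F` has not yet been measured. It differs from compound 3 by hydrogen in place of methyl on a saturated chain carbon bound to an oxygen on an aromatic ring. Going by the values given here, one measured step bears on this change: the same kind of shortening, hydrogen in place of methyl on a saturated chain carbon bound to an oxygen on an aromatic ring and a saturated chain carbon, gave a 6.5-fold higher number from compound 2 to compound 3 (0.81 log units; beyond the scatter). The change from compound 3 to compound 4 cuts the same chain one carbon shorter again, so a further rise in this assay is expected, though its size is uncertain because only a 6.5-fold higher number from compound 2 to compound 3 (0.81 log units; beyond the scatter) guides it. For compound 4 the expected step is a 2.7-fold higher number from compound 3 to compound 4 (0.43 log units; beyond the scatter). Compound 4 is therefore estimated at 700 nM, with a range from 250 nM to 2000 nM.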

Compound 4, half-maximal effective concentration: 2600 nM
For compound 4 the middle estimate is 3.7-fold (0.57 log units) below the measured one; the measured number lies above the stated range.
By their numbers in this assay, from the lowest: compound 2; then compound 3; then compounds 4 and 1 (each within the scatter of the next).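

With the methoxy group of compound 4, the group on the oxygen is one carbon shorter again, and the number shows a 10-fold higher number from compound 3 to compound 4 (1.00 log units; beyond the scatter) in a further rise, so the trend seen with a 6.5-fold higher number from compound 2 to compound 3 (0.81 log units; beyond the scatter) does not level off at ethoxy. Over the whole change, methyl in place of isopropyl on this oxygen gives a 65-fold higher number from compound 2 to compound 4 (1.81 log units; beyond the scatter) in a pair that differs in this one place, so in this assay this single position covers a wide span of numbers. No measurement here offers an explanation for this trend.

The compounds shown leave open whether a longer chain such as propyl, or a branched or ring group such as tert-butyl or cyclopropyl, on the same oxygen would bring the number below that of compound 2. They also leave open whether the same order would hold if chlorine took the place of the trifluoromethyl group.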